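The compounds below may be only part of what the source reports. "The series", "measured", "known", "first", "only" and "open" are said of these compounds alone.

Of the compounds shown here, two have so far been read in a physicochemical assay for solubility, read by spectrophotometry, using the shake flask method, with a stated time of 2 days, at pH 6.5; on this read-out higher numbers stand for higher solubility and lower numbers for lower solubility. Compound 1 (`Oc1ccc(-n2cc(-c3ccc4cc(OCC5CCCCO5)ccc4n3)nn2)cc1`) gives 3.4 ug/mL, and compound 2 (`O=C(O)c1cccc(Oc2cccc3nc(-c4cn(-c5ccc(O)c(F)c5)nn4)ccc23)c1`) gives 47.2 ug/mL. Compound 1 therefore holds the lower of the two numbers, and its gap to compound 2 lies beyond the usual scatter. The two compounds differ in more than one place, so that gap cannot be tied to any single structural change.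

The next compound, compound 3 (`NCCOc1ccc2nc(-c3cn(-c4ccc(O)cc4)nn3)ccc2c1`), keeps the core of compound 1 and changes only its side chain: aminomethyl in place of oxan-2-yl on a saturated chain carbon bound to an oxygen on an aromatic ring. Aminomethyl takes the place of oxan-2-yl on a saturated chain carbon bound to an oxygen on an aromatic ring, turning (oxan-2-yl)methoxy into 2-aminoethoxy. Going by the values given here, no measured pair shows this change, so the expectation rests on the structural change itself and on the low reading of compound 1 at 3.4 ug/mL. A rise beyond the scatter in this assay is expected, though its size is quite uncertain. The expected step is a 10-fold higher number from compound 1 to compound 3 (1.01 log units; beyond the scatter). For compound 3 the estimated value is 35 ug/mL, with an expected range of 8 ug/mL to 150 ug/mL.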

Compound 3, solubility: 3.7 ug/mL
Beside the measured number, compound 3's estimate is 9.5-fold (0.98 log units) above it, outside the stated range (below it).
By their numbers in this assay, from the lowest: compounds 1 and 3 (each within the scatter of the next); then compound 2.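

Going by these compounds alone, at this position, on a saturated chain carbon bound to an oxygen on an aromatic ring, putting aminomethyl in place of oxan-2-yl gives a 1.1-fold higher number from compound 1 to compound 3 (0.04 log units; within the scatter) in this assay, the first comparison that isolates a single place. Turning (oxan-2-yl)methoxy into 2-aminoethoxy takes away a six-membered non-aromatic ring and brings in a hydrogen-bond donor, yet compound 1 and compound 3 remain within the scatter of each other, so this exchange on the shared core gives no separation on this read-out. Nothing available here accounts for that outcome.

On these data alone, whether a carboxylic acid, a longer chain ending in an amine, or a morpholine at this same place would separate from compound 1 in this assay remains open, as does whether aminomethyl would give the same result on a different core. Compound 2 still differs from compound 1 and from compound 3 in more than one place, so the structural feature that goes with its reading also remains unresolved.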